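Paw edema in the rat: from pyridin-3-yl to pyridin-4-yl

The compounds below may be only part of what the source reports. "The series", "measured", "known", "first", "only" and "open" are said of these compounds alone.

Three hydrazones have been measured in a functional assay on the whole organism (strain Wistar) for inhibition, with Rattus norvegicus as the target, read by paw edema, with a stated time of 3 h, at a dose of 10 mg/kg by the intraperitoneal route; a lower number here means less inhibition, a higher number more inhibition at the dose given (going by the name of the read-out). Compound 1 `COc1ccc(/C=N/NC(=O)c2cccnc2Nc2cccc(C(F)(F)F)c2)cc1` gives 26.5%, compound 2 `CNc1ncccc1C(=O)N/N=C/c1ccccc1` gives 22.7%, and compound 3 `CNc1ncccc1C(=O)N/N=C/c1cccnc1` gives 27.7%. Compound 3 holds the highest of the three numbers, yet both other values lie within the scatter of it, so no order can be read from them. Among the measured compounds shown here, the one step measured between neighbouring structures, a number 5 percentage points higher from compound 2 to compound 3 (within the scatter), also stays within the scatter. Compound 4 `CNc1ncccc1C(=O)N/N=C/c1ccncc1` differs from compound 3 as follows: pyridin-4-yl in place of pyridin-3-yl on a carbon with a double bond to nitrogen. For the measured compounds named here, no measured step exchanges one pyridinyl ring for another, and the only ring exchange seen moved the read-out little. Compound 4 is therefore expected to show no step beyond the scatter in this assay, a number 1.7 percentage points lower from compound 3 to compound 4 (within the scatter), with an estimated 26% and a range of 15% to 37%.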

Compound 4, a percentage reported as inhibition, in the whole organism at one dose (the size of the read-out at that dose, not a potency): 55%
Beside the measured number, compound 4's estimate is 29 percentage points below it, outside the stated range (above it).
By their numbers in this assay, from the lowest: compounds 2, 1 and 3 (each within the scatter of the next); then compound 4.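

At the ring on a carbon with a double bond to nitrogen, this assay now separates two rings with the same atoms, joined differently, with a number 27.3 percentage points higher from compound 3 to compound 4 (beyond the scatter) on exchanging pyridin-3-yl for pyridin-4-yl. Set against phenyl, pyridin-4-yl gives a number 32.3 percentage points higher from compound 2 to compound 4 (beyond the scatter) while pyridin-3-yl stayed within the scatter of phenyl, so at this position the placing of the ring nitrogen matters and not just its presence. No evidence is available on what lies behind this step. From the compounds shown here alone, whether pyridin-2-yl or a phenyl carrying a carboxylic acid would behave likewise remains open. So does whether pyridin-4-yl would give a similar step on the core of compound 1.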